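Cell Tolerance of Three Compounds and an Untested Relative

This account rests on a few compounds, and the source may have more. Where it says the series, first, only, none or still open, it means among the compounds named here.

compound 1, `CC1CCN(c2nc(Cc3c(F)cccc3F)cc(=O)[nH]2)CC1`: > 78000 nM
compound 2, `O=c1cc(Cc2c(F)cccc2F)nc(N2CCCCCC2)[nH]1`: > 78000 nM
compound 3, `Cc1c(Cc2c(F)cccc2F)nc(N2CCC(C)CC2)[nH]c1=O`: > 75000 nM

Three compounds were tested in an ADME assay on MT4 cells (Homo sapiens) for cytotoxicity, read by MTT assay, with a stated time of 4 days; a lower number here means that less compound is tolerated, a higher number that more compound is tolerated. For compound 1 the reported value > 78000 nM is a limit of the assay, not a number. For compound 2 the value > 78000 nM is likewise a limit. For compound 3 the value > 75000 nM is also a limit. The change from compound 1 to compound 2 is azepan-1-yl in place of 4-methylpiperidin-1-yl on an aromatic carbon; the step that the two limits leave unreadable from compound 1 to compound 2 cannot be read, because both values sit at the limit of > 78000 nM in this assay, at which 2 of the 3 values shown sit. The cores of compound 1 and compound 3 differ by methyl in place of hydrogen on an aromatic carbon, and the step that the two limits leave unreadable from compound 1 to compound 3 is likewise unreadable, because one value sits at the limit of > 75000 nM in this assay, at which 1 of the 3 values shown sits, and the other at the limit of > 78000 nM in this assay, at which 2 of the 3 values shown sit.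

Compound 4, `Cc1c(Cc2c(F)cccc2F)nc(N2CCCCCC2)[nH]c1=O`, has not yet been measured in this assay. It differs from compound 3 by azepan-1-yl in place of 4-methylpiperidin-1-yl on an aromatic carbon, the same kind of change as that from compound 1 to compound 2, though here the place is also para to a methyl group. Because compound 3 sits at the limit of > 75000 nM in this assay, at which 1 of the 3 values shown sits, compound 4 is expected to remain at a limit as well, an expected step that the limit leaves unreadable from compound 3 to compound 4. The estimate for compound 4 is 80000 nM, expected to lie between 40000 nM and 200000 nM.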

Compound 4, half-maximal cytotoxic concentration: > 75000 nM
Compound 4 gave a limit, no number (the forecaster's own chance of this, stated with the estimate: 85%); the middle value is on the limit's open side.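

Compound 4 gave only a limit in this assay, not a number, so neither its step from compound 3 nor its step from compound 2 can be read. The compounds shown leave open at what concentration any of the four harms these cells, and whether the azepan-1-yl or methyl change alters that concentration.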